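Methylation of the aryl hydroxy across two cores

The compounds below may be only part of what the source reports. "The series", "measured", "known", "first", "only" and "open" are said of these compounds alone.

Compound 1 `O=C(Nc1cccc(-n2cc(-c3ccncc3)c(-c3cc(O)cc(Cl)c3)n2)c1)Nc1ccc(Cl)c(C(F)(F)F)c1` and compound 2 `COc1cc(Cl)cc(-c2nn(-c3cccc(NC(=O)Nc4ccc(Cl)c(C(F)(F)F)c4)c3)cc2-c2ccncc2)c1` share one core; in a functional assay on UACC-257 cells (Homo sapiens) for inhibition, read by sulforhodamine B assay, with a stated time of 48 h, tested at 10 uM (on this read-out higher numbers stand for a weaker effect at the one concentration tested and lower numbers for a stronger effect), compound 1 gives -40% and compound 2 gives -25.9%. The change methyl in place of hydrogen on an oxygen on an aromatic ring thus makes the step of a number 14.1 percentage points higher from compound 1 to compound 2 (beyond the scatter). Compound 3 `O=C(Nc1cccc(-n2cc(-c3ccncc3)c(-c3cc(O)cc(Cl)c3)n2)c1)c1cc(C(F)(F)F)cc(C(F)(F)F)c1` has a different core; how its core differs from the core of compound 1 is not broken down here. In this assay compound 3 gives 71%, the highest of the three numbers. Compound 4 `COc1cc(Cl)cc(-c2nn(-c3cccc(NC(=O)c4cc(C(F)(F)F)cc(C(F)(F)F)c4)c3)cc2-c2ccncc2)c1` differs from compound 3 by methyl in place of hydrogen on an oxygen on an aromatic ring, the same change at the same place as from compound 1 to compound 2. Going by the values given here, the expected step is a number 11 percentage points higher from compound 3 to compound 4 (beyond the scatter), set beside the measured one, and it rests on the step of a number 14.1 percentage points higher from compound 1 to compound 2 (beyond the scatter); the single prior instance and the unbroken-down core difference limit confidence. For compound 4 in this assay a value of 82% is estimated, within 60% to 100%.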

Compound 4, a percentage reported as activity, at one concentration (the size of the read-out at that concentration, not a potency): 79.3%
Compound 4: the middle estimate sits 2.7 percentage points above what was measured, within the range that was stated.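

Hydroxy to methoxy on the 3-chloro-5-hydroxyphenyl group gives a number 8.3 percentage points higher from compound 3 to compound 4 (within the scatter) in this assay on the second core, a step that on its own cannot be told from no change. Set beside the first core, the step does not differ measurably: the same change on two cores in this assay, a number 14.1 percentage points higher (beyond the scatter) from compound 1 to compound 2 and a number 8.3 percentage points higher (within the scatter) from compound 3 to compound 4, 5.8 percentage points apart, within the scatter of two such steps. This is consistent with the change carrying over between these two cores, but two pairs do not show that it holds on any further core, and the step on the second core alone does not establish a real shift.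

Other groups on that oxygen, such as ethyl or a longer chain, remain open. So does an amine in place of the hydroxy.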